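Nitrophenyl in place of dichlorophenyl at the thioether

The source may report more compounds than this note shows. Statements on the series, on what has been measured and on what is new or still open speak of the compounds shown alone.

Two compounds share a core and differ only in the group carried on a saturated chain carbon bound to a sulfur. In a functional assay on Ehrlich cells (Mus musculus) for cytotoxicity, read by MTT assay, with a stated time of 24 h (on this read-out lower numbers stand for stronger inhibition and higher numbers for weaker inhibition), compound 1 `Cn1nc(-c2ccc(C(F)(F)F)cc2)cc1-c1nnc(SCCOc2ccccc2F)o1` gives 35100 nM. In this assay compound 2 `Cn1nc(-c2ccc(C(F)(F)F)cc2)cc1-c1nnc(SCc2cccc(Cl)c2Cl)o1` gives 56500 nM. The step of a 1.6-fold higher number from compound 1 to compound 2 (0.21 log units; within the scatter) lies within the scatter, so compound 2 stands together with compound 1 and the two cannot be told apart on these numbers. Compound 3 `Cn1nc(-c2ccc(C(F)(F)F)cc2)cc1-c1nnc(SCc2cccc([N+](=O)[O-])c2)o1` has not been measured; it differs from compound 2 by 3-nitrophenyl in place of 2,3-dichlorophenyl on a saturated chain carbon bound to a sulfur. For the measured compounds named here, the only measured step at this place is a 1.6-fold higher number from compound 1 to compound 2 (0.21 log units; within the scatter), which stayed within the scatter, and no measured step exchanges a 2,3-dichlorophenyl for a 3-nitrophenyl. The step of a 1.1-fold lower number from compound 2 to compound 3 (0.05 log units; within the scatter) in this assay is therefore expected to be none beyond the scatter. Compound 3 is estimated at 50000 nM, with a range from 20000 nM to 130000 nM.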

Compound 3, half-maximal inhibitory concentration: > 100000 nM
Compound 3 ended at the assay's limit; the forecaster's own chance of this, stated with the estimate: 20%; middle value at least 2.0-fold (0.30 log units) away from the limit.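

In this assay compound 3 stands at a limit of the assay and not at a number: the limit of > 100000 nM in this assay, at which 1 of the 3 values shown sits. The exchange of 2,3-dichlorophenyl for 3-nitrophenyl gives an at least 1.7-fold higher number from compound 2 to compound 3 (0.24 log units; that floor lies within the scatter), so only a floor is known, and that floor does not yet separate the two compounds. For the compounds shown here, measured against the (2-fluorophenoxy)methyl group, the same 3-nitrophenyl gives an at least 2.8-fold higher number from compound 1 to compound 3 (0.45 log units; beyond the scatter), the first step at this place that clears the scatter, which shows that the group on the saturated chain carbon bound to a sulfur can shift this read-out towards weaker inhibition.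

On these data alone, how far compound 3 lies past its limit stays open. Also open, as far as these compounds go, is what an amine or a carboxylic acid in place of the nitro group, or a longer chain on the sulfur, would give in this assay.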